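The source may report more compounds than this note shows. Statements on the series, on what has been measured and on what is new or still open speak of the compounds shown alone.

In a functional assay on cells (Homo sapiens) for inhibition, read by MTT assay, with a stated time of 72 h (a lower number here means a stronger inhibitor, a higher number a weaker inhibitor), compound 1 `CCOC(=O)Cn1ncc2c(Nc3ccc(NS(=O)(=O)c4ccccc4)cc3)ncnc21` gives > 100 ug/mL, which is a limit of the assay and not a number. Compound 2 `CC(=O)Nc1ccc(Nc2ncnc3c2cnn3CC(=O)O)cc1` gives > 64 ug/mL, which is also a limit. Compound 1 therefore offers only a limit as a starting point. Compound 3 `CCOC(=O)Cn1ncc2c(Nc3ccc(NS(=O)(=O)c4ccc(Br)cc4)cc3)ncnc21` differs from compound 1 in one place: bromo in place of hydrogen on an aromatic carbon, with bromo in place of hydrogen on an aromatic carbon, para to a large group. Only a small gain in strength is expected in this assay, with the estimated step of an at least 1.2-fold lower number from compound 1 to compound 3 (0.09 log units; that floor lies within the scatter). The estimated value for compound 3 is 80 ug/mL, with an expected range of 30 ug/mL to 200 ug/mL.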

Compound 3, half-maximal inhibitory concentration: > 64 ug/mL
Compound 3 gave a limit, no number; the forecaster's own chance of this, stated with the estimate: 60%; the middle value lies beyond the limit too.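

Compound 1 and compound 3 each give only a limit in this assay, and no step can be read between them. The compounds shown leave open whether bromo in place of hydrogen changes strength in this assay at all.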